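A few compounds are considered here, and "the series" means these few. Any claim that something is new, unique, unknown or untested is made for them only; others in the source may bear on it.

In a functional assay on MCF7 cells (Homo sapiens) for antiproliferative activity, read by sulforhodamine B assay, with a stated time of 48 h (on this read-out higher numbers stand for weaker inhibition and lower numbers for stronger inhibition), compound 1 (`COc1ccc(-c2oc3c(OC)c(OC)cc(OCCCC(=O)NCc4ccccn4)c3c(=O)c2O)cc1`) reaches only a limit, > 40000 nM. Compound 2 (`CCCCN(C)C(=O)CCCCOc1cc(OC)c(OC)c2oc(-c3ccc(OC)cc3)c(O)c(=O)c12`) gives 22300 nM and compound 3 (`COc1ccc(-c2oc3c(OC)c(OC)cc(OCCCCCC(=O)N4CCN(C)CC4)c3c(=O)c2O)cc1`) gives 14100 nM, which places these two close together, with a 1.6-fold lower number from compound 2 to compound 3 (0.20 log units; within the scatter). Compound 4 (`COc1ccc(-c2oc3c(OC)c(OC)cc(OCCCCCC(=O)NCc4ccccn4)c3c(=O)c2O)cc1`) keeps the chain of compound 3 but has ((pyridin-2-yl)methyl)amino in place of 4-methylpiperazin-1-yl on a carbonyl carbon. The nearest evidence is an at least 2.8-fold lower number from compound 1 to compound 3 (0.45 log units; beyond the scatter), since compound 1 carries the same ((pyridin-2-yl)methyl)carbamoyl group on a shorter chain. That step changes the chain as well as the amide, and it gives only a floor, so it cannot be assigned to the amide alone. an at least 1.7-fold lower number from compound 1 to compound 2 (0.25 log units; that floor lies within the scatter) also mixes both changes. A modest move towards a higher number is therefore expected, though it may not clear the scatter. The expected change is a 1.7-fold higher number from compound 3 to compound 4 (0.23 log units; within the scatter). For compound 4, the estimated value is 24000 nM, with an expected range of 11000 nM to 50000 nM.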

Compound 4, half-maximal inhibitory concentration: > 40000 nM
Compound 4: a limit, no number; the forecaster's own chance of this, stated with the estimate: 35%; middle value at least 1.6-fold (0.22 log units) away from the limit.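

In this assay compound 4 gives > 40000 nM, which is a limit and not a number. Going by these compounds alone, with the chain of compound 3 held fixed, ((pyridin-2-yl)methyl)amino in place of 4-methylpiperazin-1-yl on the carbonyl carbon gives an at least 2.8-fold higher number from compound 3 to compound 4 (0.45 log units; beyond the scatter), so the change at this position alone moves the read-out beyond the scatter, which the earlier steps, mixing chain and amide, could not show. Against the butyl(methyl)carbamoyl group on the same chain there is an at least 1.7-fold higher number from compound 2 to compound 4 (0.25 log units; that floor lies within the scatter), a floor that does not separate the two.

Going by these compounds, the step between the two chain lengths bearing ((pyridin-2-yl)methyl)carbamoyl cannot be read, so what chain length does to this amide stays open: the limit of > 40000 nM in this assay, at which 2 of the 4 values shown sit. Also open, on these data alone, is how a morpholine amide or a carboxylic acid at this carbonyl carbon would read.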